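A few compounds are considered here, and "the series" means these few. Any claim that something is new, unique, unknown or untested is made for them only; others in the source may bear on it.

The series shares the core of compound 1 `C/C(=C\CC/C(C)=C/CC[C@@H]1[C@@]2(C)CCC(=O)C(C)(C)[C@H]2CC[C@@]1(C)O)CC/C=C(\C)C(=O)OCc1cn(-c2cccc(C)c2)nn1`, an ester whose triazole bears a 3-methylphenyl group. In a functional assay on A549 cells (Homo sapiens) for antiproliferative activity, read by MTT assay, with a stated time of 48 h (on this read-out lower numbers stand for stronger inhibition and higher numbers for weaker inhibition), compound 1 gives only a limit, > 150000 nM, and no number. Compound 2 `C/C(=C\CC/C(C)=C/CC[C@@H]1[C@@]2(C)CCC(=O)C(C)(C)[C@H]2CC[C@@]1(C)O)CC/C=C(\C)C(=O)OCc1cn(C[C@@H]2O[C@H](n3ccc(=O)[nH]c3=O)[C@H]3OC(C)(C)O[C@H]32)nn1` carries a larger, oxygen-rich group on the triazole in place of the aryl; in this assay compound 2 gives 15300 nM. Within the data shown here, no two measured compounds differ in a single place, so no measured step is available, and the only guidance on compound 1 is the limit of > 150000 nM in this assay, at which 1 of the 2 values shown sits.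

Compound 3 `C/C(=C\CC/C(C)=C/CC[C@@H]1[C@@]2(C)CCC(=O)C(C)(C)[C@H]2CC[C@@]1(C)O)CC/C=C(\C)C(=O)OCc1cn(-c2cccc(C(F)(F)F)c2)nn1` is the next analogue: trifluoromethyl in place of methyl on an aromatic carbon. With compound 1 sitting at a limit, the direction of the step cannot be read from the measured values, and a change of this size would be expected to move the read-out by no more than the usual scatter. The step from compound 1 to compound 3 is therefore expected to be small, a number no higher from compound 1 to compound 3 (the limit leaves the size open). Compound 3 is estimated at 150000 nM, with a range from 40000 nM to 400000 nM, and a limit rather than a number is the more likely report.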

Compound 3, half-maximal inhibitory concentration: > 150000 nM
Compound 3: only a limit was reported (the forecaster's own chance of this, stated with the estimate: 70%); the middle value lies on the limit itself.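

In this assay, among these compounds, compound 3 gives only a limit, > 150000 nM, and compound 1 is also reported only as a limit, so no step from compound 1 to compound 3 can be read. The compounds shown leave open whether any substituent on this aromatic ring gives a number rather than a limit in this assay.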